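Swapping the aryl halogen on the cyclopropane of compound 3

The source may hold more compounds than are shown below. What is called first, only, known or untested is meant among the compounds shown, and "the series" means these compounds.

Of the compounds shown here, three sharing one core have been measured in a functional assay for agonist activity at G protein-coupled receptor 88 (Homo sapiens), read by HTRF and cAMP accumulation; on this read-out higher numbers stand for an effect only at larger amounts of compound and lower numbers for an effect already at smaller amounts. Among the compounds with values here, compound 1 `CC[C@H](C)[C@@H](CN(C(=O)[C@@H]1C[C@H]1c1ccccc1)c1ccc(-c2ccccc2)cc1)NC(C)=O` gives 5.8 nM, and compound 2 `CCC(CC)C(N)CCN(C(=O)[C@@H]1C[C@H]1c1ccccc1)c1ccc(-c2ccccc2)cc1` gives 2 nM; the one step measured between neighbours is a 2.9-fold lower number from compound 1 to compound 2 (0.46 log units; beyond the scatter). Compound 3 `CC[C@H](C)[C@H](N)CN(C(=O)[C@@H]1C[C@H]1c1ccc(Cl)cc1)c1ccc(-c2ccccc2)cc1` gives 4300 nM, the highest of the three numbers, a long way beyond the scatter from either of the others.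

Compound 4 `CC[C@H](C)[C@H](N)CN(C(=O)[C@@H]1C[C@H]1c1ccc(F)c(F)c1)c1ccc(-c2ccccc2)cc1` has not been measured. It differs from compound 3 in one place: 3,4-difluorophenyl in place of 4-chlorophenyl on a saturated ring carbon. Within the data shown here, no measured step in this set touches the aryl group on the three-membered ring; the only step known concerns the chain on the amide-type nitrogen, so it does not bear on this change. Compound 1 carries a plain phenyl on that ring, but it also differs from compound 3 in the chain, so its value cannot be read as a single-point comparison.

With nothing to anchor a direction, the step is expected to be a 1.1-fold lower number from compound 3 to compound 4 (0.03 log units; within the scatter), within the scatter. Compound 4 is therefore estimated at 4000 nM, with a range from 1000 nM to 16000 nM.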

Compound 4, half-maximal effective concentration: 720 nM
Compound 4: the middle estimate sits 5.6-fold (0.74 log units) above what was measured; measured number outside the range, below it.
By their numbers in this assay, from the lowest: compound 2; then compound 1; then compound 4; then compound 3.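

In this assay, the aryl group on the saturated ring carbon of the three-membered ring can move the number by itself: 3,4-difluorophenyl in place of 4-chlorophenyl brings a 6.0-fold lower number from compound 3 to compound 4 (0.78 log units; beyond the scatter). Within the data shown here, the only earlier step concerned the chain on the amide-type nitrogen, so this is the first single-change reading at this position, and it goes beyond the scatter although the count of hydrogen-bond donors and acceptors stays the same. Nothing at hand explains why this exchange has this effect.

The exchange removes chlorine and adds two fluorines at once, so the compounds shown cannot say which part of it carries the step; 4-fluorophenyl or 3,4-dichlorophenyl on the same chain would separate these. Also open, from the compounds shown here alone, is whether the step holds on the chains of compound 1 and compound 2, which carry a plain phenyl on that ring.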